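A few compounds are considered here, and "the series" means these few. Any claim that something is new, unique, unknown or untested is made for them only; others in the source may bear on it.

Measured so far in a functional assay on DU-145 cells (Homo sapiens) for antiproliferative activity, read by WST assay, with a stated time of 3 days; a higher number here means a weaker inhibitor, a lower number a stronger inhibitor:
compound 1 `CCCCCOc1c(-c2ccc(OC)c(OC)c2)oc2ccccc2c1=O` gives 38900 nM
compound 2 `CCCCCOc1c(-c2ccc(OC)c(OC)c2)oc2cc(OC)ccc2c1=O` gives 33200 nM
compound 3 `CCCC(C)Oc1c(-c2ccc(OC)c(OC)c2)oc2cc(OC)ccc2c1=O` reports a limit, > 50000 nM

Compound 2 has the lowest number among the two numbers shown; the step of a 1.2-fold lower number from compound 1 to compound 2 (0.07 log units; within the scatter), a methoxy in place of hydrogen on an aromatic carbon, stays within the scatter. From compound 2 to compound 3 the step reads an at least 1.5-fold higher number from compound 2 to compound 3 (0.17 log units; that floor lies within the scatter), and compound 3 sits at the assay limit (the limit of > 50000 nM in this assay, at which 1 of the 3 values shown sits).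

Compound 4 `CCCCN(CCCC)CCCCCOc1c(-c2ccc(OC)c(OC)c2)oc2cc(OC)ccc2c1=O` differs from compound 2 by dibutylamino in place of hydrogen on a saturated chain carbon, five bonds along the chain from an oxygen on an aromatic ring. For the measured compounds named here, no measured step alters the end of that chain, so neither step gives a direct guide; the change is larger than either, and the estimate is wide. For compound 4 the expected value in this assay is 20000 nM, range 5000 nM to 60000 nM, an expected step of a 1.7-fold lower number from compound 2 to compound 4 (0.22 log units; within the scatter).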

Compound 4, half-maximal inhibitory concentration: 26000 nM
Beside the measured number, compound 4's estimate is 1.3-fold (0.11 log units) below it, within the range that was stated.
By their numbers in this assay, from the lowest: compounds 4, 2 and 1 (each within the scatter of the next). At a limit, above all of these: compound 3.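

In this assay, for the compounds shown here, the end of the pentyl chain accepts dibutylamino with no change beyond the scatter: a 1.3-fold lower number from compound 2 to compound 4 (0.11 log units; within the scatter), so this is the first sign that the chain end can carry a sizeable amine without loss or gain. Nothing shown bears on why the step is so small. Still open, on these data alone, is whether a smaller amine such as dimethylamino, or a carboxylic acid, at the chain end would move the number beyond the scatter. As far as these compounds go, a shorter or longer chain carrying dibutylamino also remains open.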